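A few compounds are considered here, and "the series" means these few. Any claim that something is new, unique, unknown or untested is made for them only; others in the source may bear on it.

Measured so far in an assay on isolated protein (Oryctolagus cuniculus) with Thromboxane-A synthase (Homo sapiens) as the target, tested at 1 uM; a lower number here means less inhibition, a higher number more inhibition at the concentration tested (going by the name of the read-out):
compound 1, `O=c1c2ccccc2c(-c2cccnc2)nn1CC1CCCCC1`: 98%
compound 2, `O=c1c2ccccc2c(-c2cccnc2)nn1Cc1cccc(Cl)c1`: 95%
compound 3, `COCCn1nc(-c2cccnc2)c2ccccc2c1=O`: 55%

Compound 3 stands lowest of the three numbers. Its nearest neighbour is compound 2, and the step of a number 40 percentage points lower from compound 2 to compound 3 (beyond the scatter) is beyond the scatter; the step of a number 43 percentage points lower from compound 1 to compound 3 (beyond the scatter) is larger still. By contrast the step of a number 3 percentage points lower from compound 1 to compound 2 (within the scatter) lies within the scatter, so those two sit on a level.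

Compound 4 is `O=c1c2ccccc2c(-c2cccnc2)nn1CCO`. It differs from compound 3 in one place: hydrogen in place of methyl on an oxygen on a saturated carbon. Among the measured compounds shown here, no measured step changes only this outer position; each of the three measured steps swaps the whole group on the saturated chain carbon bound to the aromatic nitrogen, and the large drops to compound 3 arose from such whole-group swaps. A single-atom trim at the oxygen is a much smaller change than any of those, so in this assay a step near the scatter is expected, with a slight lean downward given that compound 3 already sits lowest.

For compound 4 the estimated step is a number 10 percentage points lower from compound 3 to compound 4 (within the scatter). Compound 4 is therefore expected to give about 45%, within a range from 25% to 65%.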

Compound 4, a percentage reported as inhibition, at one concentration (the size of the read-out at that concentration, not a potency): 69%
Estimate against measurement, compound 4: 24 percentage points below, and the stated range ends below it.
By their numbers in this assay, from the lowest: compound 3; then compound 4; then compounds 2 and 1 (each within the scatter of the next).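

In this assay the outer end of the chain matters on its own: the step of a number 14 percentage points higher from compound 3 to compound 4 (beyond the scatter) comes from swapping methyl for hydrogen on the oxygen, so removing a single carbon moves the number beyond the scatter, and upward. This recovers only part of the gap to the larger groups, as the step of a number 26 percentage points lower from compound 2 to compound 4 (beyond the scatter) and the step of a number 29 percentage points lower from compound 1 to compound 4 (beyond the scatter) both remain, so the 2-hydroxyethyl group still stands apart from the 3-chlorophenyl and cyclohexyl groups on the same chain carbon. No measurement shown here offers an explanation for the rise from methoxy to hydroxy.

From the compounds shown here alone, it remains open whether the rise belongs to the hydroxy group itself or would also appear with an amine or a carboxylic acid at the chain end. Going by these compounds, a longer chain carrying the same hydroxy group is equally open.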